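Anilino ring substituent: chloro to methyl

A few compounds are considered here, and "the series" means these few. Any claim that something is new, unique, unknown or untested is made for them only; others in the source may bear on it.

Compound 2 `N#Cc1c(Nc2cccc(Cl)c2)nc(SCc2cn(Cc3ccccc3Cl)nn2)nc1-c1ccccc1` gives in a functional assay on MGC-803 cells (Homo sapiens) for inhibition, read by MTT assay, with a stated time of 72 h (a lower number here means a stronger inhibitor, a higher number a weaker inhibitor), a value of 15800 nM, the lowest of the two numbers gathered so far, and its nearest neighbour is compound 1 `N#Cc1c(Nc2cccc(C(F)(F)F)c2)nc(SCc2cn(Cc3ccccc3Cl)nn2)nc1-c1ccccc1`, which gives 22800 nM. Among the compounds with values here, the step of a 1.4-fold lower number from compound 1 to compound 2 (0.16 log units; within the scatter) is the only measured single-point change. Compound 3 `Cc1cccc(Nc2nc(SCc3cn(Cc4ccccc4Cl)nn3)nc(-c3ccccc3)c2C#N)c1` is the next member; it differs from compound 2 by methyl in place of chloro on an aromatic carbon. Within the data shown here, the one step that bears on this change is a 1.4-fold lower number from compound 1 to compound 2 (0.16 log units; within the scatter), which shows that exchanging the group on this aromatic carbon of the anilino ring left this assay within the scatter, so a similarly small step is expected here, with no clear direction. The step of a 1.0-fold higher number from compound 2 to compound 3 (0.01 log units; within the scatter) is therefore estimated to be small and could fall either way. For compound 3 the expected value in this assay is 16000 nM, with a range from 6000 nM to 42000 nM.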

Compound 3, half-maximal inhibitory concentration: 16200 nM
Beside the measured number, compound 3's estimate is 1.0-fold (0.01 log units) below it, within the range that was stated.
By their numbers in this assay, from the lowest: compounds 2, 3 and 1 (each within the scatter of the next).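

In this assay, methyl in place of chloro gives a 1.0-fold higher number from compound 2 to compound 3 (0.01 log units; within the scatter) and methyl in place of trifluoromethyl gives a 1.4-fold lower number from compound 1 to compound 3 (0.15 log units; within the scatter) so both new steps lie within the scatter. Where only one exchange on this aromatic carbon could be read before, three groups can now be compared there, and compound 1, compound 2 and compound 3 do not separate in this assay, with the methyl group reading like the two halogen-bearing groups. No measurement at hand offers an explanation for this result.

Still open, from the compounds shown here alone, is whether any group of a different kind on this carbon, such as an amine, a carboxylic acid or a methoxy group, would separate from compound 2 in this assay. A longer chain at the same place is equally untested in the compounds shown here.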